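This account rests on a few compounds, and the source may have more. Where it says the series, first, only, none or still open, it means among the compounds named here.

Measured so far:
- compound 1, `CC(=O)c1ccc(NC(=O)C(CC(C)C)N(C(=O)c2ccccc2)S(=O)(=O)c2ccc(C)cc2)cc1`, a functional assay for inhibition, read by spectrophotometry, with a stated time of 20 min, tested at 2 mg/mL (a higher number here means a stronger effect of the compound at the concentration tested, a lower number a weaker effect), 58.1%
- compound 2, `CC(=O)c1ccc(NC(=O)C(CC(C)C)N(C(=O)c2ccccc2)S(=O)(=O)c2ccc([N+](=O)[O-])cc2)cc1`, this assay 54.2%
- compound 3, `CC(=O)c1ccc(NC(=O)CN(C(=O)c2ccccc2)S(=O)(=O)c2ccccc2)cc1`, this assay 40.5%

Compound 3 stands lowest of the three numbers. Its nearest neighbour is compound 2, higher by a margin beyond the scatter, and the furthest is compound 1, higher by a margin also beyond the scatter. Going by the values given here, the one measured step, a number 3.9 percentage points lower from compound 1 to compound 2 (within the scatter), lies within the scatter and concerns the sulfonyl aryl only.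

Compound 4, `CC(=O)c1ccc(NC(=O)C(CC(C)C)N(C(=O)c2ccccc2)S(=O)(=O)c2ccccc2)cc1`, is to be measured in this assay. It differs from compound 3 by isobutyl in place of hydrogen on a saturated chain carbon bound to an amide-type nitrogen and a carbonyl carbon. Among the compounds with values here, no measured pair differs by this isobutyl alone, so no step bears on it directly. What the numbers do show is that both compounds carrying the isobutyl, compound 1 and compound 2, read well above compound 3, and that the sulfonyl aryl exchange from compound 1 to compound 2 changed little. Compound 4 carries the isobutyl and the unsubstituted sulfonyl aryl of compound 3, so it is expected to come out near compound 1 and compound 2, with an upward step of a number 14.5 percentage points higher from compound 3 to compound 4 (beyond the scatter) expected from compound 3.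

For compound 4 the estimate in this assay is 55%, expected between 42% and 68%.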

Compound 4, a percentage reported as inhibition, at one concentration (the size of the read-out at that concentration, not a potency): 33.7%
For compound 4 the middle estimate is 21.3 percentage points above the measured one; measured number outside the range, below it.
By their numbers in this assay, from the lowest: compounds 4 and 3 (each within the scatter of the next); then compounds 2 and 1 (each within the scatter of the next).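

In this assay, isobutyl in place of hydrogen on a saturated chain carbon bound to an amide-type nitrogen and a carbonyl carbon gives a number 6.8 percentage points lower from compound 3 to compound 4 (within the scatter) and so, with an unsubstituted sulfonyl aryl, this position shows no change beyond the scatter. The substituent on the sulfonyl aryl, which the step between compound 1 and compound 2 could not separate, now stands out with the isobutyl in place: hydrogen in place of nitro gives a number 20.5 percentage points lower from compound 2 to compound 4 (beyond the scatter) and hydrogen in place of methyl gives a number 24.4 percentage points lower from compound 1 to compound 4 (beyond the scatter), so among the isobutyl compounds the higher readings belong to the two with a substituent on that aryl, and the isobutyl alone does not account for them. No measurement at hand bears on the reason for this result.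

Still open, from the compounds shown here alone, is whether methyl or nitro on the sulfonyl aryl would read as high with hydrogen on the chain carbon, which would show whether that substituent depends on the isobutyl. Also open, going by these compounds, are how a methoxy group or an amine on that aryl would read, and how a benzyl group or a carboxylic acid would read on the chain carbon.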